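A Cyclohexylamino Addition on a Weakly Cytotoxic Core

This account rests on a few compounds, and the source may have more. Where it says the series, first, only, none or still open, it means among the compounds named here.

Going by the values given here, compound 1 `N=C(Nc1cccc(C(F)(F)F)c1)c1cc2c(-c3ccccc3)n[nH]c2cn1` is the only member of this small set that returns a number in a functional assay on PC-3 cells (Homo sapiens) for cytotoxicity, read by MTT assay, with a stated time of 72 h (a lower number here means a stronger inhibitor, a higher number a weaker inhibitor), where compound 1 gives 19900 nM. Compound 2 `COc1ccc(Cn2nc(-c3ccccc3)c3cc(C(=N)Nc4cccc(C(F)(F)F)c4)ncc32)cc1` carries 4-methoxybenzyl in place of hydrogen on an aromatic nitrogen. In this assay compound 2 reaches only a limit of the assay, > 50000 nM. Compound 3 `N=C(Nc1cccc(C(F)(F)F)c1)c1cc2cn[nH]c2cn1` has hydrogen in place of phenyl on an aromatic carbon. In this assay compound 3 likewise sits at a limit, > 50000 nM. Both changes weaken the core: an at least 2.5-fold higher number from compound 1 to compound 2 (0.40 log units; beyond the scatter) and an at least 2.5-fold higher number from compound 1 to compound 3 (0.40 log units; beyond the scatter), each resting on (the limit of > 50000 nM in this assay, at which 2 of the 3 values shown sit).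

Compound 4 `N=C(Nc1cccc(C(F)(F)F)c1)c1cc2c(-c3ccccc3)n[nH]c2c(NC2CCCCC2)n1` differs from compound 1 by cyclohexylamino in place of hydrogen on an aromatic carbon. Among the compounds with values here, neither measured step touches this place: one alters the aromatic nitrogen, the other removes the phenyl, and none of the measured compounds varies the carbon next to the ring nitrogen. The two measured steps therefore give no direct guide, and the expectation is that compound 4 stays within the scatter of compound 1, with a step of a 1.3-fold lower number from compound 1 to compound 4 (0.12 log units; within the scatter) expected. Compound 4 is estimated to give 15000 nM in this assay, within a range from 4000 nM to 50000 nM, with a real chance that only a limit is recorded.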

Compound 4, half-maximal inhibitory concentration: 25000 nM
Beside the measured number, compound 4's estimate is 1.7-fold (0.22 log units) below it; measured number inside the range.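

In this assay the new step is a 1.3-fold higher number from compound 1 to compound 4 (0.10 log units; within the scatter), so cyclohexylamino in place of hydrogen on this aromatic carbon, next to the ring nitrogen, leaves the reading of compound 1 effectively unchanged. Going by these compounds alone, this is the first information on the position, and it shows that the core can carry one six-membered non-aromatic ring of carbon here without a loss beyond the scatter, though also without any gain in cytotoxicity. The two earlier changes, made elsewhere on the core, gave an at least 2.5-fold higher number from compound 1 to compound 2 (0.40 log units; beyond the scatter) and an at least 2.5-fold higher number from compound 1 to compound 3 (0.40 log units; beyond the scatter), and both of those steps rest on a limit of the assay rather than on a number: the limit of > 50000 nM in this assay, at which 2 of the 4 values shown sit.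

With only one group on this carbon, the compounds shown leave open whether the position responds to any substituent at all, for instance a small methylamino group, a morpholine or a carboxylic acid. Going by these compounds, it also remains open whether cyclohexylamino would read the same way on the core of compound 2 or compound 3, where the other changes are present.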